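Isopropyl to Neopentyl on the Ketone of Compound 1

The source may report more compounds than this note shows. Statements on the series, on what has been measured and on what is new or still open speak of the compounds shown alone.

compound 1 `COc1cc(C(=O)O)ccc1OCCCCOc1ccc(C(=O)C(C)C)c(O)c1C` — 25.6%
compound 2 `Cc1cc(C(=O)O)ccc1OCCCCOc1ccc(C(=O)C(C)C)c(O)c1C` — 25.2%

Going by the values given here, in an assay on HEK293 cells for positive allosteric modulation of metabotropic glutamate receptor 3 (Rattus norvegicus), read by thallium flux, with a stated time of 2.5 min (a lower number here means a smaller maximal response, a higher number a larger maximal response), compound 1 stands highest of the two numbers, though the only measured step, a number 0.4 percentage points lower from compound 1 to compound 2 (within the scatter), lies within the scatter. Compound 3 `COc1cc(C(=O)O)ccc1OCCCCOc1ccc(C(=O)CC(C)(C)C)c(O)c1C` differs from compound 1 by neopentyl in place of isopropyl on a carbonyl carbon. Among the compounds with values here, the one measured step concerns the methoxy group and not the carbonyl group, so nothing measured bears on this change, and no step beyond the scatter is expected, a number 1.4 percentage points higher from compound 1 to compound 3 (within the scatter). Compound 3 is therefore estimated at 27%, expected between 12% and 42%.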

Compound 3, largest response reached (reported as percent of maximum), in percent of the reference or control that the assay uses: 109%
Compound 3: middle estimate off by 82 percentage points, on the low side, outside the stated range (above it).
By their numbers in this assay, from the lowest: compounds 2 and 1 (each within the scatter of the next); then compound 3.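

Neopentyl in place of isopropyl on a carbonyl carbon gives a number 83.4 percentage points higher from compound 1 to compound 3 (beyond the scatter) in this assay, so this position can move the maximal response strongly, which the earlier methoxy-to-methyl step did not show. Both groups are carbon-only, with no ring and no net charge, so a change confined to such a group is enough for a step of this size. No available evidence accounts for the step.

From the compounds shown here alone, it remains open how a tert-butyl, a cyclohexyl or a longer chain on this carbonyl carbon would compare with neopentyl. Going by these compounds, it is also open whether neopentyl would give a similar step on compound 2.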